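The source may report more compounds than this note shows. Statements on the series, on what has been measured and on what is new or still open speak of the compounds shown alone.

Measured compounds in a functional assay on HT-29 cells (Homo sapiens) for antiproliferative activity, read by MTT assay, with a stated time of 48 h; a higher number here means a weaker inhibitor, a lower number a stronger inhibitor:
- compound 1 `COc1ccc(-c2nn(-c3ccccc3)cc2C(=O)/C=C\Nc2ccc(F)cc2)cc1`: 7650 nM
- compound 2 `COc1ccc(N/C=C\C(=O)c2cn(-c3ccccc3)nc2-c2ccc(OC)cc2)cc1`: 8760 nM

For the measured compounds named here, compound 2 gives the highest of the two numbers so far, with compound 1 as its nearest neighbour; the gap between them is a 1.1-fold higher number from compound 1 to compound 2 (0.06 log units; within the scatter) and so does not separate the two. Compound 3 `COc1ccc(-c2nn(-c3ccccc3)cc2C(=O)/C=C\Nc2cc(OC)c(OC)c(OC)c2)cc1` is not yet measured in this assay. It differs from compound 2 in one place: 3,4,5-trimethoxyphenyl in place of 4-methoxyphenyl on an amine nitrogen.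

Going by the values given here, the only measured step, the one from compound 1 to compound 2, changes the substituent on the phenyl carried by the amine nitrogen, the same ring that is altered here, and it came out at a 1.1-fold higher number from compound 1 to compound 2 (0.06 log units; within the scatter). That step bears on the present change in place but not in kind, as the present change adds two further methoxy groups rather than swapping one substituent for another. With a single within-scatter precedent, no step beyond the scatter is expected for compound 3 in this assay in either direction. Compound 3 is expected to give 7000 nM (range 2500 nM to 20000 nM), which corresponds to an expected step of a 1.3-fold lower number from compound 2 to compound 3 (0.10 log units; within the scatter).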

Compound 3, half-maximal inhibitory concentration: 14600 nM
Compound 3: the middle estimate sits 2.1-fold (0.32 log units) below what was measured; low and high end bracket the measured number.
By their numbers in this assay, from the lowest: compounds 1, 2 and 3 (each within the scatter of the next).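

In this assay, the amine nitrogen on the double-bonded chain carbon now carries 3,4,5-trimethoxyphenyl, a larger change at this position than the earlier swap of a single substituent, and the step is a 1.7-fold higher number from compound 2 to compound 3 (0.22 log units; within the scatter). Set against the fluorinated member of the series, the same group gives a 1.9-fold higher number from compound 1 to compound 3 (0.28 log units; within the scatter), so the added methoxy groups do not separate compound 3 from either neighbour, and the three aryl groups at this position cannot be ordered from these data. No independent measurement bears on these steps, and nothing can be said about what lies behind them.

The compounds shown cover only substituted phenyl groups on this nitrogen, all with the same shared core, so it remains open whether a carboxylic acid or a basic amine on that phenyl, or a simple alkyl chain in its place, would give a step beyond the scatter. Also open, on these data alone, is whether the 4-methoxyphenyl and phenyl groups on the core, unchanged across all three compounds, would respond more strongly to replacement, for instance by a hydroxyl or a chloro substituent.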